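The source may hold more compounds than are shown below. What is called first, only, known or untested is meant among the compounds shown, and "the series" means these compounds.

Measured compounds:
Compound 1 `CCOC(=O)C1=C(Nc2ccccc2)S/C(=C\c2ccc(OC)cc2)C1=O` gives 32.9%
Compound 2 `CCOC(=O)C1=C(Nc2ccc(OC)cc2)S/C(=C\c2ccc[nH]2)C1=O` gives 27.6%
Compound 3 `CCOC(=O)C1=C(Nc2ccccc2Br)S/C(=C\c2ccc[nH]2)C1=O` gives 62.7%

All three were tested in a functional assay on JAR cells (Homo sapiens) for inhibition, read by MTT assay, with a stated time of 72 h, tested at 10 uM; a lower number here means less inhibition, a higher number more inhibition at the concentration tested (going by the name of the read-out). Compound 1 stands in the middle of the three numbers: its gap to compound 2 lies within the scatter of repeated measurements, while compound 3 sits beyond the scatter above it. Within the data shown here, the one recorded step, a number 35.1 percentage points higher from compound 2 to compound 3 (beyond the scatter), concerns the substituent on the amine nitrogen only; compounds 1 and 2 differ in two places at once, so their values show merely that they are within the scatter of each other.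

Compound 4 `CCOC(=O)C1=C(Nc2ccccc2)S/C(=C\c2cc3cnccc3[nH]2)C1=O` is the next compound. Compared with compound 1, it differs by a group of 9 heavy atoms (7 carbon, 2 nitrogen; one five-membered aromatic ring with 1 hetero atom, one six-membered aromatic ring with 1 hetero atom) in place of a group of 8 heavy atoms (7 carbon, 1 oxygen; one six-membered aromatic ring of carbon only), on a double-bonded chain carbon bound to a double-bonded ring carbon. Among the measured compounds shown here, no measured step touches this place: the only step recorded, a number 35.1 percentage points higher from compound 2 to compound 3 (beyond the scatter), lies elsewhere on the shared core and therefore gives no guidance on the direction or size of the change here. The change is judged only on the numbers of compounds 1 and 2, which sit close together.

For the measured compounds named here, with no step bearing on the change, compound 4 is expected to stay near compound 1, the estimated step being a number 3.1 percentage points higher from compound 1 to compound 4 (within the scatter), within the scatter. Compound 4 is thus estimated at 36%, in the range 16% to 56%.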

Compound 4, a percentage reported as inhibition, at one concentration (the size of the read-out at that concentration, not a potency): < 10%
Compound 4: only a limit was reported; the forecaster's own chance of this, stated with the estimate: 0%; at least 26 percentage points between middle value and limit.
By their numbers in this assay, from the lowest: compounds 2 and 1 (each within the scatter of the next); then compound 3. At a limit, below all of these: compound 4.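

In this assay, putting the group with a five-membered and a six-membered aromatic ring in place of 4-methoxyphenyl, on a double-bonded chain carbon bound to a double-bonded ring carbon, brings a number at least 22.9 percentage points lower from compound 1 to compound 4 (beyond the scatter), the first step read at this place. Among these compounds, compound 4 gives < 10%, which is a limit of the assay and not a number: the limit of < 10% in this assay, at which 1 of the 4 values shown sits. Until now the only recorded step concerned the substituent on the amine nitrogen, a number 35.1 percentage points higher from compound 2 to compound 3 (beyond the scatter), so this result adds a second place on the shared core where a single change moves the number beyond the scatter.

The compounds shown leave open which feature of the entering group goes with the lower number, as this place is covered by one step that exchanges the whole group at once. On these data alone, it also stays open whether the same step would appear with 2-bromophenyl on the amine nitrogen, and how a phenyl ring carrying an amine or a carboxylic acid would read at this place.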